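The source may report more compounds than this note shows. Statements on the series, on what has been measured and on what is new or still open speak of the compounds shown alone.

Among the measured compounds shown here, in a physicochemical assay for solubility, at pH 7.4 (on this read-out lower numbers stand for lower solubility and higher numbers for higher solubility), two compounds on a shared core have numbers so far. Compound 1 `CNC1(C)CN(c2cc3c(cc2F)c(=O)c(C(=O)O)cn3C2CC2)C1` gives 0.7 ug/mL and compound 2 `CN[C@H]1CN(c2cc3c(cc2F)c(=O)c(C(=O)O)cn3C2CC2)[C@@H]1C` gives 9.2 ug/mL as the higher of the two. Compound 3 `C[C@@H]1[C@@H](N(C)C)CN1c1cc2c(cc1F)c(=O)c(C(=O)O)cn2C1CC1` has yet to be measured. It differs from compound 2 by a single change (methyl in place of hydrogen on an amine nitrogen) with methyl in place of hydrogen on an amine nitrogen, which turns methylamino into dimethylamino. For the measured compounds named here, the only measured step is a 13-fold higher number from compound 1 to compound 2 (1.12 log units; beyond the scatter) and it is large, beyond the scatter. That step swaps one group for another of equal size on an aromatic carbon, so it is not this change. It gives no direction here, but it does warn that close relatives can differ widely in this assay and so calls for a broad range. The expected move is a 1.3-fold lower number from compound 2 to compound 3 (0.12 log units; within the scatter) and it stays within the scatter. For compound 3 the estimated value is 7 ug/mL with an expected range from 1.5 ug/mL to 30 ug/mL on this read-out.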

Compound 3, solubility: 96.3 ug/mL
Estimate against measurement, compound 3: 14-fold (1.14 log units) below; the whole stated range lies below it.
By their numbers in this assay, from the lowest: compound 1; then compound 2; then compound 3.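

In this assay, methyl in place of hydrogen on an amine nitrogen, which turns methylamino into dimethylamino, gives a 10-fold higher number from compound 2 to compound 3 (1.02 log units; beyond the scatter) and so shows that one added methyl at this nitrogen can shift the read-out well beyond the usual scatter. Compound 3 now stands highest of the three, and a 140-fold higher number from compound 1 to compound 3 (2.14 log units; beyond the scatter) is the widest gap in this small set, so the group on the aromatic carbon matters greatly here. No measurement shown accounts for the rise.

On these data alone, this change appears in a single pair, so it stays open whether dimethylamino on the core of compound 1 would move the number the same way. As far as these compounds go, it is also open whether an ethyl group or an acetyl group on this nitrogen would continue the rise or reverse it.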